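From an arylamine to a piperidine on the shared core

The compounds below may be only part of what the source reports. "The series", "measured", "known", "first", "only" and "open" are said of these compounds alone.

For the measured compounds named here, compound 2 `O=C1C(Nc2ccccc2F)=CC(=O)c2c1nc1n2[C@H]2OC[C@@H](O)[C@H]2OC1` gives 2000 nM in a functional assay on MGC-803 cells (Homo sapiens) for inhibition, read by sulforhodamine B assay (a higher number here means a weaker inhibitor, a lower number a stronger inhibitor), the higher of the two numbers known here, while compound 1 `CCCc1ccc(NC2=CC(=O)c3nc4n(c3C2=O)[C@H]2OC[C@@H](O)[C@H]2OC4)cc1` gives 1560 nM, a gap that lies within the scatter. Compound 3 `O=C1C=C(NC2CCCCC2)C(=O)c2c1nc1n2[C@H]2OC[C@@H](O)[C@H]2OC1` reaches only the limit of > 8000 nM, so no number is known for it. Compound 4 `O=C1C(N2CCCCC2)=CC(=O)c2c1nc1n2[C@H]2OC[C@@H](O)[C@H]2OC1` differs from compound 2 by piperidin-1-yl in place of (2-fluorophenyl)amino on a double-bonded ring carbon. One measured step speaks to this change: an at least 5.1-fold higher number from compound 1 to compound 3 (0.70 log units; beyond the scatter), where trading an aromatic ring for a saturated one drove the value to the limit (the limit of > 8000 nM in this assay, at which 1 of the 3 values shown sits). Compound 4 likewise loses its aromatic ring, and also its hydrogen-bond donor, so a comparable weakening is expected, namely a 5.0-fold higher number from compound 2 to compound 4 (0.70 log units; beyond the scatter). Compound 4 is therefore estimated at 10000 nM, between 3000 nM and 30000 nM, and may itself end up at the limit.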

Compound 4, half-maximal inhibitory concentration: > 4000 nM
Compound 4 was reported as a limit; the forecaster's own chance of this, stated with the estimate: 60%; the middle value is on the limit's open side.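

In this assay, compound 4 gives > 4000 nM, which is a limit and not a number. Replacing (2-fluorophenyl)amino with piperidin-1-yl on this double-bonded ring carbon therefore gives only a floor, an at least 2.0-fold higher number from compound 2 to compound 4 (0.30 log units; that floor lies within the scatter), so this change is not shown to weaken the compound, although a larger loss remains possible. The change removes both the aromatic ring and the hydrogen-bond donor, and this single step cannot separate the two. As far as these compounds go, whether a morpholine ring or a dimethylamino group at this carbon would give a measurable number remains open.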